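The source may report more compounds than this note shows. Statements on the series, on what has been measured and on what is new or still open speak of the compounds shown alone.

Measured so far in a functional assay on HEK293 cells with prostaglandin E2 receptor EP4 subtype (Rattus norvegicus) as the target, read by cAMP accumulation; on this read-out lower numbers stand for an effect already at smaller amounts and higher numbers for an effect only at larger amounts of compound:
compound 1, `O=C(O)CCCCCCN1C(=O)CCC1CCC(O)Cc1cccc(Cl)c1` — 8.8 nM
compound 2, `O=C(O)CCCCCCN1C(=O)CC[C@@H]1CC[C@@H](O)Cc1cccc(-c2ccccc2)c1` — 195 nM

Compound 2 has the highest number of the two; its nearest neighbour is compound 1, whose number in this assay is lower, and the gap between them lies beyond the usual scatter. Going by the values given here, no pair of measured compounds differs in a single place, so no step can be read off directly; the two values show only that the compound carrying phenyl in this place gives the higher number.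

Compound 3, `N#Cc1cccc(C[C@H](O)CC[C@H]2CCC(=O)N2CCCCCCC(=O)O)c1`, is not yet measured. It differs from compound 2 in one place: cyano in place of phenyl on an aromatic carbon. Compound 1 carries chloro in the same place and gives 8.8 nM, whereas compound 2 with phenyl gives 195 nM. On that basis compound 3 is expected to land nearer compound 1 than compound 2, a decrease beyond the scatter. The step expected in this assay is a 13-fold lower number from compound 2 to compound 3 (1.11 log units; beyond the scatter). The estimate for compound 3 is 15 nM, with a range from 4 nM to 60 nM.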

Compound 3, half-maximal effective concentration: 96 nM
The estimate for compound 3 lay 6.4-fold (0.81 log units) below the measured number, outside the stated range (above it).
By their numbers in this assay, from the lowest: compound 1; then compound 3; then compound 2.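

In this assay, going by these compounds alone, cyano in place of phenyl on this aromatic carbon, meta to a large group, gives a 2.0-fold lower number from compound 2 to compound 3 (0.31 log units; beyond the scatter), the first matched reading at this position, and a modest one. Removing the six-membered aromatic ring and going from six heavy atoms to two, with one hydrogen-bond acceptor entering, therefore moves the number only a little, and compound 3 stays at 96 nM, while compound 1, with chloro, gives 8.8 nM; compound 1 is drawn without defined stereochemistry, so it differs from compound 3 in more than one place and no step can be read between them. Nothing measured here bears on the reason for the step from phenyl to cyano.

The compounds shown leave open whether chloro keeps its low number when it carries the same stereochemistry as compound 2 and compound 3. They also leave open how a methoxy group or a fluorine atom on this aromatic carbon would compare with cyano, and therefore whether the number follows the size of the group or its kind.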